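This account rests on a few compounds, and the source may have more. Where it says the series, first, only, none or still open, it means among the compounds named here.

Compound 2 `CN(C)C1CCN(c2nccnc2OC2CN(c3ccc4ccccc4n3)C2)CC1` is taken as the starting point. In a physicochemical assay for solubility, in phosphate buffer, at pH 7.4 (a lower number here means a less soluble compound, a higher number a more soluble compound), compound 2 gives 500000 nM, level at the digits shown with compound 1 `OCC1CCN(c2nccnc2OC2CN(c3cnc4ccccc4n3)C2)CC1`, which in this assay gives 500000 nM; together these are the highest of the three numbers recorded. Among the compounds with values here, the furthest of the three is compound 3 `c1ccc2nc(N3CC(Oc4nccnc4-c4ccncc4)C3)ccc2c1`, which in this assay gives 56000 nM, and the single measured step that joins the two is an 8.9-fold lower number from compound 2 to compound 3 (0.95 log units; beyond the scatter).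

Compound 4 `c1ccc2ncc(-c3nccnc3OC3CN(c4ccc5ccccc5n4)C3)cc2c1` differs from compound 2 at the same position: quinolin-3-yl in place of 4-(dimethylamino)piperidin-1-yl on an aromatic carbon. Within the data shown here, the one step that bears on this change is an 8.9-fold lower number from compound 2 to compound 3 (0.95 log units; beyond the scatter), where an aromatic ring replaced the same 4-(dimethylamino)piperidin-1-yl group. Quinolin-3-yl is a larger bicyclic aromatic group than pyridin-4-yl and carries fewer hydrogen-bond acceptors, so a step in the same direction, and at least as large, is expected in this assay; compound 4 is therefore expected to show a 50-fold lower number from compound 2 to compound 4 (1.70 log units; beyond the scatter). The estimated value for compound 4 in this assay is 10000 nM, with a range from 2000 nM to 50000 nM.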

Compound 4, solubility: < 1000 nM
Compound 4 ended at the assay's limit; the forecaster's own chance of this, stated with the estimate: 10%; middle value at least 10-fold (1.00 log units) away from the limit.
By their numbers in this assay, from the lowest: compound 3; then compounds 1 and 2 (each within the scatter of the next). At a limit, below all of these: compound 4.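

In this assay compound 4 gives < 1000 nM, which is a limit of the assay and not a number. The earlier compounds shown here showed only the exchange of 4-(dimethylamino)piperidin-1-yl for an aromatic ring, whereas the two new steps, an at least 500-fold lower number from compound 2 to compound 4 (2.69 log units; beyond the scatter) and an at least 56-fold lower number from compound 3 to compound 4 (1.74 log units; beyond the scatter), show that the choice of aromatic group at this position also moves the read-out, with quinolin-3-yl and pyridin-4-yl not interchangeable here. Both steps are open-ended, and how far compound 4 lies past the limit cannot be told: the limit of < 1000 nM in this assay, at which 1 of the 4 values shown sits.

Going by these compounds, what remains open is whether a pyridin-3-yl group would stand with compound 3 or with compound 4, which would separate the second ring of quinolin-3-yl from the place of its attachment. Also open, on these data alone, is how a morpholine ring, or a pyridine ring carrying an amine, would compare with compound 2 at this position.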